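This account rests on a few compounds, and the source may have more. Where it says the series, first, only, none or still open, it means among the compounds named here.

Working notes on the oxazolidinone series.

Among the measured compounds shown here, compound 2 `Cc1ccc(Oc2ccc(C(=O)N3CCOC3=O)cc2)cc1` is the only member with a number in an assay on HEK293 cells for inhibition of N-acylethanolamine-hydrolyzing acid amidase (Rattus norvegicus), read by LC-MS, with a stated time of 30 min; on this read-out higher numbers stand for weaker inhibition and lower numbers for stronger inhibition: compound 2 gives 6400 nM. Compound 1 `O=C1OCCN1C(=O)c1ccc(Oc2ccc(O)cc2)cc1` reaches only a limit of the assay in this assay, > 20000 nM. For the measured compounds named here, the one measured step, an at least 3.1-fold lower number from compound 1 to compound 2 (0.49 log units; beyond the scatter), rests on that limit, as the limit of > 20000 nM in this assay, at which 1 of the 2 values shown sits, records.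

Compound 3 `CCCCOc1ccc(C(=O)N2CCOC2=O)cc1` differs from compound 2 by butyl in place of 4-methylphenyl on an oxygen on an aromatic ring. Going by the values given here, no measured step touches this kind of change: the only step known alters a substituent on the distal ring while keeping it, whereas here the ring itself is removed and a chain enters. The direction of the step from compound 2 to compound 3 in this assay therefore cannot be read from the data, and a step of any size, in either direction, or none beyond the scatter, remains possible.

As a working estimate, compound 3 is expected at 9000 nM, between 2500 nM and 30000 nM, which would mean a step of a 1.4-fold higher number from compound 2 to compound 3 (0.15 log units; within the scatter).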

Compound 3, half-maximal inhibitory concentration: 1340 nM
Compound 3: the middle estimate sits 6.7-fold (0.83 log units) above what was measured, outside the stated range (below it).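

The earlier step only changed a substituent on a distal ring that stayed in place, whereas this result shows that on an oxygen on an aromatic ring the ring itself can give way to an open chain: butyl in place of 4-methylphenyl gives a 4.8-fold lower number from compound 2 to compound 3 (0.68 log units; beyond the scatter) in this assay. Of the compounds shown, compound 3 has the lowest number, and neither other compound goes against this. Butyl in place of 4-hydroxyphenyl gives an at least 14-fold lower number from compound 1 to compound 3 (1.17 log units; beyond the scatter), but this step is a bound and not a size, because it rests on the limit of the assay reached by compound 1: the limit of > 20000 nM in this assay, at which 1 of the 3 values shown sits.

Whether butyl is the preferred length at this oxygen remains open, as the compounds shown include neither ethyl nor a longer chain such as octyl. Also open, as far as these compounds go, is how a chain ending in an amine or a carboxylic acid would read here.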